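The compounds below may be only part of what the source reports. "The series", "measured", "known", "first", "only" and "open" are said of these compounds alone.

Measured compounds:
compound 1 `COc1cccc(NC2=CC(=O)c3nc4n(c3C2=O)[C@H]2OC[C@@H](O)[C@H]2OC4)c1`, 4280 nM in a functional assay on HeLa cells (Homo sapiens) for inhibition, read by sulforhodamine B assay; on this read-out lower numbers stand for stronger inhibition and higher numbers for weaker inhibition
compound 2 `O=C1C=C(Nc2ccc(C(F)(F)F)cc2)C(=O)c2c1nc1n2[C@H]2OC[C@@H](O)[C@H]2OC1`, a limit only, > 8000 nM in this assay
compound 3 `CCOc1ccccc1NC1=CC(=O)c2c(nc3n2[C@H]2OC[C@@H](O)[C@H]2OC3)C1=O`, 8300 nM in this assay

Compound 1 holds the lower of the two numbers, and compound 3 stands apart from it by a gap that the usual scatter covers. Compound 2 reaches only the limit (the limit of > 8000 nM in this assay, at which 1 of the 3 values shown sits).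

Compound 4 `O=C1C=C(N2CCCCC2)C(=O)c2c1nc1n2[C@H]2OC[C@@H](O)[C@H]2OC1` differs from compound 1 by piperidin-1-yl in place of (3-methoxyphenyl)amino on a double-bonded ring carbon. For the measured compounds named here, the one measured step, an at least 1.8-fold higher number from compound 1 to compound 2 (0.27 log units; that floor lies within the scatter), swaps one aryl group for another and does not clearly leave the scatter; no measured step removes the aryl ring and its amine hydrogen altogether. The change to compound 4 is therefore unguided, and a weakening step a 2.1-fold higher number from compound 1 to compound 4 (0.32 log units; beyond the scatter) is expected in this assay. Compound 4 is estimated at 9000 nM, between 3000 nM and 25000 nM.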

Compound 4, half-maximal inhibitory concentration: > 16000 nM
Compound 4: only a limit was reported; the forecaster's own chance of this, stated with the estimate: 50%; at least 1.7-fold (0.24 log units) between middle value and limit.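

At this double-bonded ring carbon, piperidin-1-yl in place of (3-methoxyphenyl)amino gives an at least 3.7-fold higher number from compound 1 to compound 4 (0.57 log units; beyond the scatter) in this assay, the first step shown that lies beyond the scatter. Inhibition thus weakens when the aromatic ring and the amine hydrogen leave together, which the swap of one aryl group for another could not show. Compound 4 carries only a limit, so the full size of this step stays unknown: the limit of > 16000 nM in this assay, at which 1 of the 4 values shown sits.

Which of the two losses counts remains open. A cyclohexylamino group, keeping the amine hydrogen, or a methyl(phenyl)amino group, keeping the aromatic ring, would separate them.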